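Swapping a Benzylamino Group for a Phenylamino Group

The compounds below may be only part of what the source reports. "The series", "measured", "known", "first", "only" and "open" are said of these compounds alone.

Compound 1 `N[C@H]1CC[C@H](Nc2nc(Nc3ccc(Cl)cc3)c3ncn(C4CCCCC4)c3n2)CC1` gives 140 nM in the assay below
Compound 2 `CCCCn1cnc2c(NCc3cccc(Cl)c3)nc(N[C@H]3CC[C@H](N)CC3)nc21` gives 350 nM in the same assay

In a functional assay on EOL1 cells (Homo sapiens) for inhibition, read by fluorescence, with a stated time of 72 h (on this read-out higher numbers stand for weaker inhibition of growth and lower numbers for stronger inhibition of growth), compound 2 has the higher of the two numbers, beyond the usual scatter. One change leads from compound 2 to compound 3 `CCCCn1cnc2c(Nc3ccc(Cl)cc3)nc(N[C@H]3CC[C@H](N)CC3)nc21` (4-chlorophenyl in place of 3-chlorobenzyl on a nitrogen on an aromatic ring), namely 4-chlorophenyl in place of 3-chlorobenzyl on a nitrogen on an aromatic ring. Going by the values given here, no measured pair shows this change alone. Among the compounds with values here, the only guide is compound 1, which also carries 4-chlorophenyl and gives 140 nM as its value. An estimated 2.2-fold lower number from compound 2 to compound 3 (0.34 log units; beyond the scatter) is expected, a modest move towards a lower number. Compound 3 is estimated at 160 nM (expected range 50 nM to 500 nM).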

Compound 3, concentration for 50% growth inhibition: 50 nM
The estimate for compound 3 lay 3.2-fold (0.51 log units) above the measured number, and the stated range covers the measured number.
By their numbers in this assay, from the lowest: compound 3; then compound 1; then compound 2.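

In this assay, going by these compounds alone, 4-chlorophenyl in place of 3-chlorobenzyl gives a 7.0-fold lower number from compound 2 to compound 3 (0.85 log units; beyond the scatter) and so offers the first reading of this change on its own. Butyl in place of cyclohexyl on an aromatic nitrogen gives a 2.8-fold lower number from compound 1 to compound 3 (0.45 log units; beyond the scatter) and shows that a second place on the shared core also moves the number.

The first change alters both the position of the chlorine and the link to the ring, so 3-chlorophenyl or 4-chlorobenzyl would be needed to tell these apart. No measurement here explains either step.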